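Methanesulfonamido for hydroxy on the piperidine ring

The source may hold more compounds than are shown below. What is called first, only, known or untested is meant among the compounds shown, and "the series" means these compounds.

Compound 1 `COc1cc(COc2cc(N)c(Cl)cc2C(=O)CCCCN2CCC(C)CC2)cc(OC)c1` in a functional assay for antagonist activity at 5-hydroxytryptamine receptor 4 (Rattus norvegicus) (on this read-out higher numbers stand for higher potency (the scale is a negative logarithm) and lower numbers for lower potency), gives 8.3. Compound 2 `COc1cc(COc2cc(N)c(Cl)cc2C(=O)CCCCN2CCC(O)CC2)cc(OC)c1` carries hydroxy in place of methyl on a saturated ring carbon; in this assay compound 2 gives 8.3. The step of no change at the digits printed from compound 1 to compound 2 (within the scatter) lies within the scatter, so compound 2 stands level with compound 1 on the numbers available and is the closest measured point. Compound 3 `COc1cc(COc2cc(N)c(Cl)cc2C(=O)CCCCN2CCC(NS(C)(=O)=O)CC2)cc(OC)c1` is not yet measured. Its change from compound 2 is methanesulfonamido in place of hydroxy on a saturated ring carbon. Among the measured compounds shown here, only the step from compound 1 to compound 2 bears on this position, and it was flat; no measured step covers a group of this size there. The expected step of a number 0.20 log units lower from compound 2 to compound 3 (within the scatter) in this assay is therefore close to none beyond the scatter, with wider uncertainty than the earlier step. Compound 3 is estimated at 8.1 in this assay, within 7.4 to 8.8.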

Compound 3, negative logarithm of the antagonist equilibrium constant: 8.4
Compound 3: middle estimate off by 0.30 log units, on the low side; the range from low to high includes it.
By their numbers in this assay, from the lowest: compounds 1, 2 and 3 (each within the scatter of the next).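

In this assay, the saturated ring carbon three ring bonds from the ring nitrogen accepts a much larger group than the methyl and hydroxy of the earlier pair: methanesulfonamido, with 5 heavy atoms against 1 for hydroxy, gives a number 0.10 log units higher from compound 2 to compound 3 (within the scatter) and, set against methyl, a number 0.10 log units higher from compound 1 to compound 3 (within the scatter). Compound 1, compound 2 and compound 3 therefore stand level, and the flat reading at this position now spans three groups, one of them carrying 2 double bonds outside aromatic rings. Nothing available explains this flatness.

As far as these compounds go, whether an amine or a carboxylic acid on this ring carbon would also leave the read-out level remains open. So does whether a longer chain on the sulfonyl group, such as butanesulfonamido in place of methanesulfonamido, would hold it there.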